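Hydroxy in place of hydrogen: cytotoxicity notes on a chalcone step

The compounds below may be only part of what the source reports. "The series", "measured", "known", "first", "only" and "open" are said of these compounds alone.

Of the compounds shown here, three have been read in an ADME assay on RAW264.7 cells (Mus musculus) for cytotoxicity, read by MTT assay, with a stated time of 24 h, tested at 5 ug/mL; a lower number here means a stronger effect, a higher number a weaker effect of the compound at the concentration tested. Compound 1 `COc1ccc(/C=C/C(=O)c2ccc(OC)c(OC)c2)cc1` gives 78.9%, the second highest of the three numbers. Compound 3 `COc1ccc(C(=O)/C=C/c2cccc(OC)c2OC)c(O)c1` gives 69.7%, a number that sits within the usual scatter of the number for compound 1. Compound 2 `COc1ccc(CCCc2cccc(O)c2)c(OC)c1` gives 95.9%, a number beyond the scatter above compound 1 and the highest of the set. Among the compounds with values here, no pair of measured compounds differs in a single place, so no measured step is available for guidance.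

Compound 4 `COc1ccc(/C=C/C(=O)c2ccc(OC)c(OC)c2)cc1O` differs from compound 1 by hydroxy in place of hydrogen on an aromatic carbon, on an aromatic carbon ortho to a methoxy group. A small step is expected in this assay, within the scatter and if anything slightly downward, estimated as a number 3.9 percentage points lower from compound 1 to compound 4 (within the scatter). Compound 4 is therefore expected to give about 75%, with a range of 60% to 90%.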

Compound 4, a percentage reported as activity, at one concentration (the size of the read-out at that concentration, not a potency): 73%
For compound 4 the middle estimate is 2 percentage points above the measured one, within the range that was stated.
By their numbers in this assay, from the lowest: compounds 3, 4 and 1 (each within the scatter of the next); then compound 2.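

Hydroxy in place of hydrogen on an aromatic carbon, ortho to a methoxy group, gives a number 5.9 percentage points lower from compound 1 to compound 4 (within the scatter) in this assay, the first single-place step of the series. On the core of compound 1, this position therefore accepts the change with no shift beyond the scatter. No measurement shown accounts for the size of this step.

From the compounds shown here alone, whether an amine or a carboxylic acid at this position would also stay within the scatter remains open. So does the outcome of hydroxy on another aromatic carbon of the core.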